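From methylcarbamoyl to ethoxy on compound 2

A few compounds are considered here, and "the series" means these few. Any claim that something is new, unique, unknown or untested is made for them only; others in the source may bear on it.

In a functional assay on MDA-MB-468 cells (Homo sapiens) for antiproliferative activity, read by MTT assay, with a stated time of 24 h (on this read-out higher numbers stand for weaker inhibition and lower numbers for stronger inhibition), compound 1 `CNC(=O)c1ccccc1Oc1nc(Nc2ccccc2F)ncc1Br` gives > 50000 nM, which is a limit of the assay and not a number. Compound 2 `CNC(=O)c1ccccc1Oc1nc(Nc2cccc(C)c2)ncc1Br` gives 18600 nM. Compound 3 `CNC(=O)c1ccccc1Oc1nc(Nc2ccc(C)cc2C)ncc1Br` gives 40700 nM, leaving compound 2 with the lower of the two actual numbers. Compound 4 `CCOc1ccccc1Oc1nc(Nc2cccc(C)c2)ncc1Br` has ethoxy in place of methylcarbamoyl on an aromatic carbon. The measured steps changed only the group on the nitrogen, namely an at least 2.6-fold lower number from compound 1 to compound 2 (0.42 log units; beyond the scatter) and a 2.2-fold higher number from compound 2 to compound 3 (0.34 log units; beyond the scatter). Neither alters the methylcarbamoyl, so they guide only the size of the step, and the direction remains uncertain. The expected change is a 1.3-fold higher number from compound 2 to compound 4 (0.13 log units; within the scatter), a modest move towards a higher number. For compound 4 the estimated value is 25000 nM, with an expected range of 9000 nM to 50000 nM.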

Compound 4, half-maximal inhibitory concentration: 31400 nM
Estimate against measurement, compound 4: 1.3-fold (0.10 log units) below; measured number inside the range.
By their numbers in this assay, from the lowest: compounds 2, 4 and 3 (each within the scatter of the next, the first and the last beyond it). At a limit, above all of these: compound 1.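

In this assay the exchange at this position reads a 1.7-fold higher number from compound 2 to compound 4 (0.23 log units; within the scatter) and is the only step shown that touches the methylcarbamoyl. Ethoxy, with 0 hydrogen-bond donors, thus replaces methylcarbamoyl, with its donor, without a difference beyond the scatter in this one pair. Nothing measured here accounts for this step.

From the compounds shown here alone, whether an amine, a carboxylic acid or a longer alkoxy chain on this aromatic carbon would read differently stays open. So does whether the exchange behaves alike with the other groups on the nitrogen.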